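Methoxy to Bromo on the Pendant Aryl Ring

The source may report more compounds than this note shows. Statements on the series, on what has been measured and on what is new or still open speak of the compounds shown alone.

Of the compounds shown here, three sharing one core have been measured in a functional assay on MCF7 cells (Homo sapiens) for cytotoxicity, read by MTT assay, with a stated time of 72 h; on this read-out lower numbers stand for stronger inhibition and higher numbers for weaker inhibition. Compound 1 `O=C(Nc1ccc(Oc2ccnc3[nH]ccc23)c(F)c1)c1nn(-c2ccc(Br)cc2)ccc1=O` gives 11600 nM, and compound 2 `Cn1ccc2c(Oc3ccc(NC(=O)c4nn(-c5ccc(Br)cc5)ccc4=O)cc3)ccnc21` gives 16300 nM. For compound 3 `COc1ccc(-n2ccc(=O)c(C(=O)Nc3ccc(Oc4ccnc5c4ccn5C)c(F)c3)n2)cc1` this assay returned only a limit, > 60000 nM (the limit of > 60000 nM in this assay, at which 1 of the 3 values shown sits). Compound 4 `Cn1ccc2c(Oc3ccc(NC(=O)c4nn(-c5ccc(Br)cc5)ccc4=O)cc3F)ccnc21` has not yet been measured. It differs from compound 3 by bromo in place of methoxy on an aromatic carbon, para to a large group. Going by the values given here, no measured pair shows this change directly, so its size can only be expected, not read off. Both measured compounds that carry the bromo group sit near one another in this assay, and compound 4 carries it as well. Compound 4 is therefore expected to come in at 13000 nM, between 6000 nM and 30000 nM. That estimate would mean a step of an at least 4.6-fold lower number from compound 3 to compound 4 (0.66 log units; beyond the scatter) toward stronger inhibition.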

Compound 4, half-maximal inhibitory concentration: 33600 nM
Estimate against measurement, compound 4: 2.6-fold (0.41 log units) below, outside the stated range (above it).
By their numbers in this assay, from the lowest: compounds 1 and 2 (each within the scatter of the next); then compound 4. At a limit, above all of these: compound 3.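

The change from 4-methoxyphenyl to 4-bromophenyl can be sized only as a floor, an at least 1.7-fold lower number from compound 3 to compound 4 (0.25 log units; that floor lies within the scatter), and compound 3 remains a limit: the limit of > 60000 nM in this assay, at which 1 of the 4 values shown sits. With bromo in place, the other two single changes both raise the number modestly: fluoro in place of hydrogen gives a 2.1-fold higher number from compound 2 to compound 4 (0.31 log units; beyond the scatter), and methyl in place of hydrogen on the aromatic nitrogen gives a 2.9-fold higher number from compound 1 to compound 4 (0.46 log units; beyond the scatter). No line of the data explains these steps, so the size of the bromo gain remains unsettled. As far as these compounds go, what an amine or a carboxylic acid would give at this position remains open, as does how far compound 3 lies beyond its limit.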